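Phenylglycinate ester in the chlorobenzyl sub-series

A few compounds are considered here, and "the series" means these few. Any claim that something is new, unique, unknown or untested is made for them only; others in the source may bear on it.

Measured compounds in a functional assay on HCT-116 cells (Homo sapiens) for inhibition, read by fluorescence, with a stated time of 48 h; a higher number here means a weaker inhibitor of growth, a lower number a stronger inhibitor of growth:
compound 1 `CC(C)(COC(=O)[C@@H](N)c1ccccc1)COC1(c2ccc(Cl)cc2)c2ccccc2C(=O)N1Cc1ccccc1` gives 15000 nM
compound 2 `CC(C)(CO)COC1(c2ccc(Cl)cc2)c2ccccc2C(=O)N1Cc1ccc(Cl)cc1` gives 50000 nM
compound 3 `CC(=O)OCC(C)(C)COC1(c2ccc(Cl)cc2)c2ccccc2C(=O)N1Cc1ccc(Cl)cc1` gives 35000 nM

Compound 3 stands second highest of the three numbers in this assay. Its nearest neighbour is compound 2, and the step of a 1.4-fold lower number from compound 2 to compound 3 (0.15 log units; within the scatter) shows that exchanging the free hydroxyl for the acetate does nothing beyond the scatter. Compound 1 lies furthest from compound 3, with a lower number that exceeds the scatter; compound 1 and compound 3 differ in two places, so only their two values can be set side by side.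

Compound 4 `CC(C)(COC(=O)[C@@H](N)c1ccccc1)COC1(c2ccc(Cl)cc2)c2ccccc2C(=O)N1Cc1ccc(Cl)cc1` has not been measured. It differs from compound 3 by amino(phenyl)methyl in place of methyl on a carbonyl carbon. For the measured compounds named here, no single step among the measured compounds carries exactly this change. What bears on it is the comparison of compound 1 with compound 3: both carry an ester at the same position, and the compound bearing the amino(phenyl)methyl ester shows the lower number. Going by the values given here, the other point of difference between compound 1 and compound 4 is a chlorine on the benzyl group, a change for which the series gives no step. On this basis compound 4 is expected to come out near compound 1 rather than near compound 3, and the step of a 1.9-fold lower number from compound 3 to compound 4 (0.29 log units; within the scatter) is expected to be modest but beyond the scatter. Compound 4 is estimated at 18000 nM, within a range of 8000 nM to 40000 nM.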

Compound 4, concentration for 50% growth inhibition: 8000 nM
Estimate against measurement, compound 4: 2.3-fold (0.35 log units) above; the measured number falls inside the stated range.
By their numbers in this assay, from the lowest: compounds 4 and 1 (each within the scatter of the next); then compounds 3 and 2 (each within the scatter of the next).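

In this assay, amino(phenyl)methyl in place of methyl on a carbonyl carbon gives a 4.4-fold lower number from compound 3 to compound 4 (0.64 log units; beyond the scatter) as a single-place change, so the ester effect that compound 1 and compound 3 could only hint at across two differences can now be read directly. Measured from the free hydroxyl, the (amino(phenyl)methyl)carbonyl group gives a 6.3-fold lower number from compound 2 to compound 4 (0.80 log units; beyond the scatter) while acetyl gives only a 1.4-fold lower number from compound 2 to compound 3 (0.15 log units; within the scatter) and so, among these three compounds, capping this oxygen as an ester is not enough in itself and the change beyond the scatter appears only with the amino(phenyl)methyl group. Chloro in place of hydrogen on an aromatic carbon gives a 1.9-fold lower number from compound 1 to compound 4 (0.27 log units; within the scatter) and so this pair shows no readable effect of that chlorine, with the ester carrying the difference in this small set.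

The compounds shown do not separate the amine from the phenyl ring within the amino(phenyl)methyl group, which an aminomethyl or a benzyl group on the same carbonyl carbon would do, and the role of the defined stereocentre also stays open. No supporting data are available to explain the change at this ester.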